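Swapping the Amide Aryl Ring on a Weak Scaffold

A few compounds are considered here, and "the series" means these few. Any claim that something is new, unique, unknown or untested is made for them only; others in the source may bear on it.

Compound 1 `O=C(Nc1ccc(Cl)c(-c2nnc3c(Cl)cccn23)c1)c1ccccn1` carries a pyridin-2-yl group on the carbonyl carbon of its amide. In a functional assay on T47D cells (Homo sapiens) for antiproliferative activity, read by MTT assay, with a stated time of 72 h (a lower number here means a stronger inhibitor, a higher number a weaker inhibitor), compound 1 reaches only the limit of the test, reported as > 100000 nM. Compound 2 `Cc1nc(C(=O)Nc2ccc(Cl)c(-c3nnc4c(Cl)cccn34)c2)cs1` differs from it solely in the group on that carbonyl carbon. In this assay compound 2 likewise sits at a limit, reported as > 100000 nM. The step that the two limits leave unreadable from compound 1 to compound 2 thus stays unreadable, and the evidence so far is simply (the limit of > 100000 nM in this assay, at which 2 of the 2 values shown sit).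

Compound 3 `O=C(Nc1ccc(Cl)c(-c2nnc3c(Cl)cccn23)c1)c1cccnc1` continues the same kind of exchange: pyridin-3-yl in place of 2-methyl-1,3-thiazol-4-yl on a carbonyl carbon. Within the data shown here, the single measured step bears on this change, but neither of its ends gave a number, so it shows no movement off the limit for any swap of the group on the carbonyl carbon. Compound 3 is therefore expected to remain at the limit too, with an estimated 150000 nM and a range from 50000 nM to 1000000 nM. The expected step that the limit leaves unreadable from compound 2 to compound 3 is accordingly none beyond the scatter, should a number appear at all.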

Compound 3, half-maximal inhibitory concentration: > 100000 nM
Compound 3: no number, only a limit; the forecaster's own chance of this, stated with the estimate: 85%; the middle value is on the limit's open side.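

Among these compounds, compound 3 also gives only a limit rather than a number, so no step among compound 1, compound 2 and compound 3 can be read: the limit of > 100000 nM in this assay, at which 3 of the 3 values shown sit. As far as these compounds go, what stays open is whether any group on this carbonyl carbon would give a measurable value in this assay.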